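A few compounds are considered here, and "the series" means these few. Any claim that something is new, unique, unknown or untested is made for them only; others in the source may bear on it.

Measured in a functional assay on PANC-1 cells (Homo sapiens) for antiproliferative activity; a higher number here means a weaker inhibitor, a lower number a stronger inhibitor:
- compound 1 `CC[C@H](C)[C@H]1C(=O)N[C@H](Cc2ccc(O)c(Br)c2)C(=O)N[C@@H](C(C)(C)O)C(=O)O[C@H](c2ccccc2)[C@H](C)/C=C/C=C(\C)[C@H](OC)C/C=C(\C)C(=O)N1C`: 11.4 nM
- compound 2 `CC[C@H](C)[C@H]1C(=O)N[C@H](Cc2cc(Cl)c(O)c(Cl)c2)C(=O)N[C@@H](C(C)C)C(=O)O[C@H](c2ccccc2)[C@H](C)/C=C/C=C(\C)[C@H](OC)C/C=C(\C)C(=O)N1C`: 137 nM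

Of these two, compound 2 has the higher number, beyond the scatter of compound 1, and so is the weaker inhibitor. Compound 3 `CC[C@H](C)[C@H]1C(=O)N[C@H](Cc2cc(Cl)c(O)c(Cl)c2)C(=O)N[C@@H](C(C)(C)O)C(=O)O[C@H](c2ccccc2)[C@H](C)/C=C/C=C(\C)[C@H](OC)C/C=C(\C)C(=O)N1C` departs from compound 2 by hydroxy in place of hydrogen on a saturated chain carbon bound to two saturated chain carbons and a saturated ring carbon and this is hydroxy in place of hydrogen on a saturated chain carbon bound to two saturated chain carbons and a saturated ring carbon. The 1-hydroxy-1-methylethyl group already stands in compound 1 at 11.4 nM but that compound also differs from compound 2 in a second place, so it is only a rough guide. An estimated 6.9-fold lower number from compound 2 to compound 3 (0.84 log units; beyond the scatter) is expected, towards a lower number and beyond the scatter. Compound 3 is expected at 20 nM with 6 nM to 70 nM as its estimated range.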

Compound 3, half-maximal inhibitory concentration: 11.3 nM
Beside the measured number, compound 3's estimate is 1.8-fold (0.25 log units) above it, within the range that was stated.
By their numbers in this assay, from the lowest: compounds 3 and 1 (each within the scatter of the next); then compound 2.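

In this assay, isopropyl to 1-hydroxy-1-methylethyl gives a large step (a 12-fold lower number from compound 2 to compound 3 (1.08 log units; beyond the scatter)), which isolates this hydroxy in place of hydrogen as a single change at this carbon. With that group present, 3,5-dichloro-4-hydroxyphenyl in place of 3-bromo-4-hydroxyphenyl gives a step within the scatter (a 1.0-fold lower number from compound 1 to compound 3 (0.00 log units; within the scatter)). No evidence bearing on the reason for the hydroxy step is at hand. From the compounds shown here alone, whether a methoxy or an amine at this carbon would give a similar number remains open. So does whether the hydroxy step would be the same size with 3-bromo-4-hydroxyphenyl.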